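The source may report more compounds than this note shows. Statements on the series, on what has been measured and on what is new or still open speak of the compounds shown alone.

Measured compounds in an assay on isolated protein for inhibition of Amine oxidase [flavin-containing] B (Bos taurus); on this read-out lower numbers stand for stronger inhibition and higher numbers for weaker inhibition:
compound 2 `CCC(=O)N1N=C(c2ccc(C)cc2)CC1c1ccc(C)cc1` gives 100000 nM;
compound 1 `CCC(=O)N1N=C(c2ccccc2)CC1c1ccc(Cl)cc1` gives 100000 nM;
compound 3 `CCC(=O)N1N=C(c2ccc(C)cc2)CC1c1ccc(OC)cc1` gives 100000 nM.

Compound 2 thus stands level with compound 1 and compound 3 in this assay; the three values do not differ beyond the scatter, so no one of them can be called stronger or weaker than another.

Compound 4 `CCC(=O)N1N=C(c2ccc(OC)cc2)CC1c1ccc(C)cc1` differs from compound 2 in one place: methoxy in place of methyl on an aromatic carbon, on an aromatic carbon of a six-membered aromatic ring of carbon only, para to a large group. Put one bond further out, the change reads 4-methylphenyl to 4-methoxyphenyl.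

Among the measured compounds shown here, one measured step bears on this change. From compound 2 to compound 3 the same swap of methoxy for methyl was made, but on the other aromatic ring of the shared core, and it gave no change at the digits printed from compound 2 to compound 3 (within the scatter). For the measured compounds named here, that is the only guide available; nothing measured shows this swap on the ring of compound 4 itself. With that step as the reference, no movement beyond the scatter is expected for compound 4, so the expected step is no change at the digits printed from compound 2 to compound 4 (within the scatter).

Compound 4 is therefore estimated at 100000 nM in this assay, with a range from 50000 nM to 200000 nM.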

Compound 4, half-maximal inhibitory concentration: 10000 nM
The estimate for compound 4 lay 10-fold (1.00 log units) above the measured number, and the stated range ends above it.
By their numbers in this assay, from the lowest: compound 4; then compounds 1, 2 and 3 (each within the scatter of the next).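

In this assay the para position on the aromatic ring of compound 4 responds to the swap of methoxy for methyl, giving a 10-fold lower number from compound 2 to compound 4 (1.00 log units; beyond the scatter) and so stronger inhibition. Among the compounds shown here, the same swap on the other aromatic ring gave no change at the digits printed from compound 2 to compound 3 (within the scatter) and so did not separate the two compounds, which means the outcome of this change depends on which ring of the shared core carries it, something the earlier compounds alone could not reveal. Nothing available here offers any measurement that accounts for the difference between the two rings.

The compounds shown leave open whether the stronger inhibition is particular to methoxy or would also appear with other groups at this place, such as a hydroxyl, an amine, or the longer ethoxy chain. They also leave open what would happen with methoxy on both aromatic rings at once, and whether the step seen here would hold on a core carrying something other than the methyl that compound 4 keeps on its other ring.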